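Compound 3: dropping the azetidinyl amide tail

A few compounds are considered here, and "the series" means these few. Any claim that something is new, unique, unknown or untested is made for them only; others in the source may bear on it.

Measured in a functional assay on Ishikawa cells (Homo sapiens) for antiproliferative activity, read by CCK-8 assay, with a stated time of 48 h; a lower number here means a stronger inhibitor, a higher number a weaker inhibitor:
Compound 1 `O=C(/C=C/CN1CC(Oc2ccc(Oc3c(-c4ccc(F)cc4)sc4cc(O)ccc34)cc2)C1)N1CCCC1`: 9150 nM
Compound 2 `O=C(/C=C/CN1CC(Oc2ccc(Oc3c(-c4ccc(F)cc4)sc4cc(O)ccc34)cc2)C1)N1CCC1`: 5450 nM

Among the compounds with values here, compound 2 stands level with compound 1, as their two values lie within the scatter of each other, and no other measured compound is available for comparison. The next compound is compound 3 `C=C(C)C(=O)N1CC(Oc2ccc(Oc3c(-c4ccc(F)cc4)sc4cc(O)ccc34)cc2)C1`, which has (1-methylethenyl)carbonyl in place of 3-((azetidin-1-yl)carbonyl)prop-2-en-1-yl on an amine nitrogen in a ring.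

Within the data shown here, only one measured step bears on this change, and only weakly: a 1.7-fold lower number from compound 1 to compound 2 (0.23 log units; within the scatter). That step swapped azetidin-1-yl for pyrrolidin-1-yl within the group that leaves here, whereas compound 3 loses the whole group. From the compounds shown here alone, the data therefore give no direction, and no step beyond the scatter is expected, although a larger shift of either sign remains open. The expected step is a 1.4-fold lower number from compound 2 to compound 3 (0.13 log units; within the scatter). In this assay, the estimate for compound 3 is 4000 nM, with an expected range of 1000 nM to 15000 nM.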

Compound 3, half-maximal inhibitory concentration: 14200 nM
For compound 3 the middle estimate is 3.6-fold (0.55 log units) below the measured one, and the stated range covers the measured number.
By their numbers in this assay, from the lowest: compounds 2, 1 and 3 (each within the scatter of the next, the first and the last beyond it).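

In this assay, within the data shown here, putting (1-methylethenyl)carbonyl in place of 3-((azetidin-1-yl)carbonyl)prop-2-en-1-yl on an amine nitrogen in a ring gives a 2.6-fold higher number from compound 2 to compound 3 (0.42 log units; beyond the scatter), the first step beyond the scatter, though only a modest one, so the whole group on this nitrogen can be exchanged with little movement in the number. Against the 3-((pyrrolidin-1-yl)carbonyl)prop-2-en-1-yl group, the same replacement gives a 1.6-fold higher number from compound 1 to compound 3 (0.19 log units; within the scatter), so compound 3 separates from compound 2 but not from compound 1, and the size of the change at this position depends on which amide serves as the reference. Nothing on hand accounts for this difference between the two comparisons.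

The compounds shown leave open whether a plain methyl group or an unsubstituted amine nitrogen at this position would give a number close to these three, which would show how much of the activity rests with the shared core. Also open, from the compounds shown here alone, is how a longer chain before the amide, or a carboxylic acid in place of the azetidinyl amide, would read in this assay.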